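A few compounds are considered here, and "the series" means these few. Any claim that something is new, unique, unknown or untested is made for them only; others in the source may bear on it.

Compound 1 `CC(C)COC(=O)Nc1ccc([Se]C#N)cc1` gives 26900 nM
Compound 2 `N#C[Se]c1ccc(NC(=O)Oc2ccc(F)cc2)cc1` gives 19800 nM
Compound 3 `N#C[Se]c1ccc(NC(=O)OCc2ccc([N+](=O)[O-])cc2)cc1` gives 7700 nM

These numbers come from an ADME assay on BEAS-2B cells (Homo sapiens) for cytotoxicity, read by MTT assay, with a stated time of 72 h; a lower number here means a stronger inhibitor of growth, a higher number a weaker inhibitor of growth. Compound 1 has the highest number of the three; compound 2 sits within the scatter of it, so the two cannot be ordered, while compound 3 lies beyond the scatter with a lower number. Compound 4 `CCOC(=O)Nc1ccc([Se]C#N)cc1` differs from compound 1 by methyl in place of isopropyl on a saturated chain carbon bound to an oxygen next to a carbonyl group. Going by the values given here, no measured pair shows this change on the shared core, so nothing measured tells its size. A small step is expected: a 1.1-fold higher number from compound 1 to compound 4 (0.05 log units; within the scatter), not beyond the scatter and in no certain direction. Compound 4 is therefore estimated at 30000 nM, with a plausible range from 12000 nM to 75000 nM.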

Compound 4, concentration for 50% growth inhibition: 21700 nM
For compound 4 the middle estimate is 1.4-fold (0.14 log units) above the measured one; low and high end bracket the measured number.
By their numbers in this assay, from the lowest: compound 3; then compounds 2, 4 and 1 (each within the scatter of the next).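

Going by these compounds alone, putting methyl in place of isopropyl on a saturated chain carbon bound to an oxygen next to a carbonyl group gives a 1.2-fold lower number from compound 1 to compound 4 (0.09 log units; within the scatter) in this assay and is the first direct test of this place on the shared core. The isobutyl and ethyl forms cannot be told apart here, so compound 1 and compound 4 cannot be ordered. No measurement available here accounts for this result.

As far as these compounds go, whether a much longer chain, such as octyl, would give a number beyond the scatter remains open. So does the effect of an amine or a carboxylic acid on the chain.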